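Arylamino replacement of ethoxy on the pyrrolinone-type core

A few compounds are considered here, and "the series" means these few. Any claim that something is new, unique, unknown or untested is made for them only; others in the source may bear on it.

Three compounds of this series carry the same core, differing at one double-bonded ring carbon. Compound 1 `O=C(C1=C(O)C(=O)N(CCCn2ccnc2)C1c1ccc(Br)cc1)c1ccccc1` bears a hydroxyl there; in a functional assay on U2OS cells (Homo sapiens) for antiproliferative activity, read by MTT assay, with a stated time of 72 h (on this read-out higher numbers stand for weaker inhibition and lower numbers for stronger inhibition), compound 1 gives "not active" (no number reported), with no number reported. Compound 2 `CCOC1=C(C(=O)c2ccccc2)C(c2ccc(Br)cc2)N(CCCn2ccnc2)C1=O` bears an ethoxy group; in this assay compound 2 gives 21900 nM, the lowest of the two numbers reported, its nearest neighbour being compound 3 `O=C(C1=C(Nc2ccc(F)cc2)C(=O)N(CCCn2ccnc2)C1c1ccc(Br)cc1)c1ccccc1`, which in this assay gives 30000 nM. Going by the values given here, the only single-point step measured is a 1.4-fold higher number from compound 2 to compound 3 (0.14 log units; within the scatter), a change that stays within the scatter.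

Compound 4 `O=C(C1=C(Nc2ccc(I)cc2)C(=O)N(CCCn2ccnc2)C1c1ccc(Br)cc1)c1ccccc1` is not yet measured; it differs from compound 2 by (4-iodophenyl)amino in place of ethoxy on a double-bonded ring carbon. The step from compound 2 to compound 3 bears directly on it, since both put an arylamino group at the same ring carbon, and that step did not leave the scatter. Compound 4 is therefore expected to sit close to compound 2 and compound 3, with a step of a 1.3-fold higher number from compound 2 to compound 4 (0.11 log units; within the scatter) no larger than the scatter. The estimate for compound 4 in this assay is 28000 nM, within 10000 nM to 80000 nM.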

Compound 4, half-maximal inhibitory concentration: 12000 nM
Compound 4: the middle estimate sits 2.3-fold (0.37 log units) above what was measured, and the stated range covers the measured number.
By their numbers in this assay, from the lowest: compounds 4, 2 and 3 (each within the scatter of the next, the first and the last beyond it).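

In this assay, going by these compounds alone, a 2.5-fold lower number from compound 3 to compound 4 (0.40 log units; beyond the scatter) is the first step to leave the scatter, so the para-free reading is simple: with the arylamino group held at the double-bonded ring carbon, iodo in place of fluoro on an aromatic carbon is a measurable, if modest, change. Against the ethoxy group, the picture stays flat: a 1.8-fold lower number from compound 2 to compound 4 (0.26 log units; within the scatter), so (4-iodophenyl)amino is not separated from ethoxy at this ring carbon, even though the two arylamino compounds are separated from each other. No measurement at hand accounts for the gap between the iodo and fluoro compounds.

Going by these compounds, two halogens do not make a trend, and a chloro or bromo group on the same aromatic ring remains open. Also open, on these data alone, is how an unsubstituted phenylamino group, or a non-aromatic amine such as morpholine, at this ring carbon compares with ethoxy.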